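A Methyl Added to the Anilino Ring of Compound 3

This account rests on a few compounds, and the source may have more. Where it says the series, first, only, none or still open, it means among the compounds named here.

For the measured compounds named here, compound 3 `Cc1ccc(C(=O)c2sc(Nc3ccccc3)c(C(=O)O)c2C)cc1` is the one compound of this set with a numerical read-out: in a functional assay, with a stated time of 150 min, tested at 5 ug/mL (on this read-out higher numbers stand for a stronger effect at the one concentration tested and lower numbers for a weaker effect), compound 3 gives 0.26%. Compound 1 `COC(=O)c1c(Nc2ccc(C)cc2)sc(C(=O)c2ccc(C)cc2)c1C` is recorded in this assay as "not active" (no number reported), and compound 2 `COc1ccc(C(=O)c2sc(Nc3ccc(C)cc3)c(C(=O)O)c2C)cc1` as "not active" (no number reported), so neither of these two carries a number. Compound 4 `Cc1ccc(Nc2sc(C(=O)c3ccc(C)cc3)c(C)c2C(=O)O)cc1` has not yet been measured in this assay. It differs from compound 3 in one place: methyl in place of hydrogen on an aromatic carbon. With compound 3 standing at 0.26%, the step from compound 3 to compound 4 is expected to be small in either direction and to stay within the scatter, as a number 0.2 percentage points higher from compound 3 to compound 4 (within the scatter). Compound 4 is accordingly estimated to give 0.5% in this assay, within a range from 0% to 10%.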

Compound 4, a percentage reported as activity, at one concentration (the size of the read-out at that concentration, not a potency): "not active" (no number reported)
For compound 4 the study gives words and no number; no gap can be computed for the estimate.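

For the compounds shown here, compound 4 is recorded as "not active" (no number reported) in this assay and compound 3 gives 0.26% there, so no step between compound 3 and compound 4 can be read. The compounds shown leave open how far methyl in place of hydrogen shifts this read-out. Nothing shown bears on an explanation.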